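The compounds below may be only part of what the source reports. "The series", "measured", "known", "first", "only" and "open" are said of these compounds alone.

The compounds measured so far, with their values in a functional assay on MCF7 cells (Homo sapiens) for inhibition, read by sulforhodamine B assay, with a stated time of 48 h; a higher number here means a weaker inhibitor of growth, a lower number a stronger inhibitor of growth:

Compound 1 `CC1=CC[C@H](C(C)(C)NC(=S)N/N=C/c2ccccc2)CC1`: 84400 nM

Compound 2 `CC1=CC[C@H](C(C)(C)NC(=S)N/N=C/c2ccc(Cl)cc2)CC1`: a limit of the assay, > 100000 nM

Compound 2 therefore stands only at a limit in this assay, with no number of its own, and the move from compound 1 to it is known only as a floor: an at least 1.1-fold higher number from compound 1 to compound 2 (0.07 log units; that floor lies within the scatter). That floor rests on (the limit of > 100000 nM in this assay, at which 1 of the 2 values shown sits).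

Compound 3 `CC1=CC[C@H](C(C)(C)NC(=S)N/N=C/c2ccco2)CC1` differs from compound 2 in one place: furan-2-yl in place of 4-chlorophenyl on a carbon with a double bond to nitrogen. Among the compounds with values here, no measured step bears directly on this exchange. Within the data shown here, the one measured step, a chloro in place of hydrogen on an aromatic carbon, set only a floor within the scatter, so the replacement of the whole 4-chlorophenyl by furan-2-yl is judged from compound 1 and compound 2 alone, whose values sit close to each other and near the limit of this assay.

On that basis compound 3 is expected to fall near the same region, and the step from compound 2 to compound 3 is estimated at an at least 1.1-fold lower number from compound 2 to compound 3 (0.04 log units; that floor lies within the scatter). The estimate for compound 3 in this assay is 90000 nM, with a range from 40000 nM to 200000 nM, and a real chance that only a limit is reported again.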

Compound 3, concentration for total growth inhibition: 53700 nM
Compound 3: the middle estimate sits 1.7-fold (0.22 log units) above what was measured; measured number inside the range.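

In this assay, the furan-2-yl ring shows that a five-membered aromatic ring with 1 hetero atom can stand on this carbon with a double bond to nitrogen, and that compound 3 keeps a number of its own, which allows a full reading against the phenyl of compound 1: the exchange amounts to a 1.6-fold lower number from compound 1 to compound 3 (0.20 log units; within the scatter), so phenyl and furan-2-yl cannot be told apart here. Compound 2 stands at a limit of the assay, > 100000 nM, which is not a number. Against that limit, the exchange of 4-chlorophenyl for furan-2-yl can be read only as a floor, an at least 1.8-fold lower number from compound 2 to compound 3 (0.27 log units; that floor lies within the scatter), and this reading rests on a single limit: the limit of > 100000 nM in this assay, at which 1 of the 3 values shown sits.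

The compounds shown therefore leave open whether any group at this place moves the number in this assay beyond the scatter, and how far the 4-chlorophenyl of compound 2 truly lies from the other two. They also leave open what an amine or a carboxylic acid on the phenyl ring would do, and what a change in the shared core away from this place would bring.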